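The compounds below may be only part of what the source reports. "The series", "measured", "known", "first", "only" and "open" are said of these compounds alone.

Of the compounds shown here, two have been tested in an assay on CHO-K1 cells for displacement of a labelled ligand from 5-hydroxytryptamine receptor 7 (Homo sapiens), read by scintillation counting; a lower number here means a stronger inhibitor, a higher number a weaker inhibitor. Compound 1, with the structure `COc1ccccc1N1CCN(CCCCC(=O)NCc2ccccc2-c2cccc(F)c2)CC1`, gives 34.7 nM. Compound 2, with the structure `COc1ccccc1N1CCN(CCCCCC(=O)NCc2ccccc2-c2ccccc2)CC1`, gives 43.7 nM. Of these two numbers compound 1 has the lower one, yet the gap between the two sits within the usual scatter of repeated measurements, so they count as equivalent and neither compound can be called the stronger binder. The two structures also differ in more than one place at once, so no single structural change can be read from that pair.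

Compound 3, with the structure `COc1ccccc1N1CCN(CCCCC(=O)NCc2ccccc2-c2cccc(C)c2)CC1`, has not yet been measured. It differs from compound 1 in one place only: methyl in place of fluoro on an aromatic carbon. Going by the values given here, nothing among the measured compounds shows what such a swap does here. With a one-atom group replaced by another one-atom group that carries no donors, acceptors or charge, a step of no size beyond the scatter is expected for compound 3 in this assay, in either direction, written as a 1.2-fold higher number from compound 1 to compound 3 (0.06 log units; within the scatter). Compound 3 is therefore estimated at 40 nM, with a range from 15 nM to 110 nM.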

Compound 3, inhibition constant: 47.6 nM
For compound 3 the middle estimate is 1.2-fold (0.08 log units) below the measured one, within the range that was stated.
By their numbers in this assay, from the lowest: compounds 1, 2 and 3 (each within the scatter of the next).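

This is the only pair among the compounds shown that differs in one place, and in this assay it gives a 1.4-fold higher number from compound 1 to compound 3 (0.14 log units; within the scatter). The two compounds therefore count as equivalent, so for this shared core, the 3-fluorophenyl and 3-methylphenyl forms cannot be told apart by this measurement. For this one position, on an aromatic carbon meta to a large group, the result shows that either of these one-atom groups is compatible with binding in the same range, though no available measurement explains why the two read alike.

On these data alone, neither compound here shows what the same position does when it carries plain hydrogen with this chain length, so it remains unknown whether fluoro or methyl contributes anything to binding, and compound 2 cannot settle this because it also differs in its chain. Also open, as far as these compounds go, is whether a group of another kind at this place, such as an amine, a carboxylic acid or a trifluoromethyl group, would produce a step beyond the scatter, or whether this position accepts such groups just as readily.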